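Plasma free fraction across fluorinated methoxyphenyl analogues

The source may hold more compounds than are shown below. What is called first, only, known or untested is meant among the compounds shown, and "the series" means these compounds.

Measured so far:
- Compound 1, `COc1ccc(F)cc1C1CCN(c2ccn3c(CC4CC4)nnc3c2Cl)CC1`: in an ADME assay on a cell-free system (plasma, Rattus norvegicus) for protein binding (on this read-out lower numbers stand for a smaller free fraction and higher numbers for a larger free fraction), compound 1 gives < 0.01, which is a limit of the assay.
- Compound 2, `COc1c(F)cccc1C1CCN(c2ccn3c(CC4CC4)nnc3c2Cl)CC1`: in this assay compound 2 gives < 0.01, again a limit of the assay.

Both values sit at the limit of < 0.01 in this assay, at which 2 of the 2 values shown sit, so the step that the two limits leave unreadable from compound 1 to compound 2 cannot be sized. Among the compounds with values here, compound 2 therefore stands at the limit, alongside the one other value available; no step beyond the scatter has been resolved.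

Compound 3, `COc1c(C2CCN(c3ccn4c(CC5CC5)nnc4c3Cl)CC2)ccc(F)c1F`, differs from compound 2 by fluoro in place of hydrogen on an aromatic carbon, read one bond further out as 3-fluoro-2-methoxyphenyl to 3,4-difluoro-2-methoxyphenyl. Within the data shown here, the only measured step, from compound 1 to compound 2, is a related change on the same aromatic ring, yet its size is unreadable. For compound 3 the expected step is a step that the limit leaves unreadable from compound 2 to compound 3, none beyond the scatter, most likely again reported as a limit. The estimate for compound 3 is 0.005, with range 0.002 to 0.012.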

Compound 3, unbound fraction: < 0.01
Compound 3 gave a limit, no number; the forecaster's own chance of this, stated with the estimate: 85%; the middle value does not contradict the limit.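

In this assay no new step can be read among compound 1, compound 2 and compound 3, as all three sit at the same limit: the limit of < 0.01 in this assay, at which 3 of the 3 values shown sit.

The compounds shown leave open how the free fractions of these three compounds compare, and whether fluoro in place of hydrogen on the aromatic carbon makes any difference.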